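A few compounds are considered here, and "the series" means these few. Any claim that something is new, unique, unknown or untested is made for them only; others in the source may bear on it.

Measured so far:
- compound 1, `COc1cc(NC(C)CCCNC(=O)NNC(=O)Nc2cc(C(F)(F)F)cc(C(F)(F)F)c2)c2ncccc2c1`: 13000 nM
- compound 2, `COc1cc(NC(C)CCCNC(=O)NNC(=O)Nc2ccc(O)cc2)c2ncccc2c1`: 111000 nM
- compound 3, `COc1cc(NC(C)CCCNC(=O)Nc2cc(C(F)(F)F)cc(C(F)(F)F)c2)c2ncccc2c1`: 4100 nM

In a functional assay on CCRF-CEM cells (Homo sapiens) for inhibition, read by MTT assay, with a stated time of 72 h (a higher number here means a weaker inhibitor, a lower number a stronger inhibitor), compound 2 gives 111000 nM, the highest of the three numbers. Its nearest neighbour is compound 1, whose value in this assay is 13000 nM; the furthest is compound 3 with 4100 nM. Both gaps lie beyond the usual scatter, so compound 2 is the weakest inhibitor of the set. Among the compounds with values here, no single-point step between measured compounds is available.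

Compound 4, `COc1cc(NC(C)CCCNC(=O)Nc2ccc(Cl)cc2)c2ncccc2c1`, is the next compound to be measured in this assay. Its difference from compound 2 is 4-chlorophenyl in place of ((4-hydroxyphenyl)carbamoyl)amino on an amide-type nitrogen. The arylaminocarbonyl extension is thus removed, and the aryl group now sits directly on the amide-type nitrogen, as it does in compound 3, though with a different substitution.

Compound 3 gives 4100 nM and compound 1 gives 13000 nM, so the shorter arrangement has so far gone with the lower numbers. A drop beyond the scatter is therefore expected, with the step of a 7.4-fold lower number from compound 2 to compound 4 (0.87 log units; beyond the scatter) taken as the likely size. For compound 4 the estimate in this assay is 15000 nM, within a range of 4000 nM to 50000 nM.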

Compound 4, half-maximal inhibitory concentration: 24000 nM
Beside the measured number, compound 4's estimate is 1.6-fold (0.20 log units) below it; measured number inside the range.
By their numbers in this assay, from the lowest: compound 3; then compounds 1 and 4 (each within the scatter of the next); then compound 2.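

In this assay, within the data shown here, the step of a 4.6-fold lower number from compound 2 to compound 4 (0.67 log units; beyond the scatter) is the first reading at this amide-type nitrogen in which only one place changes, and it shows that the group there affects the number beyond the scatter. Compounds 1, 2 and 3 could not show this, as no two of them differ in one place. The change nonetheless has several parts: 4-chlorophenyl in place of ((4-hydroxyphenyl)carbamoyl)amino shortens the group from the 11 heavy atoms of the leaving group to the 7 of the entering one, removes all its hydrogen-bond donors and acceptors, and replaces the hydroxyl with chlorine, and no measurement here explains the step or assigns it to any one of these differences.

The shown compounds leave open how much of the step belongs to the lost carbamoylamino extension and how much to the exchange of ring substituent, a question that compounds differing from compound 2 or compound 4 in only one of these features could separate. Also open, as far as these compounds go, is how the number responds to other groups on the phenyl ring at this nitrogen, such as an amine or a carboxylic acid.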